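This account rests on a few compounds, and the source may have more. Where it says the series, first, only, none or still open, it means among the compounds named here.

Measured compounds and their values:
Compound 1 `CCCCc1ccc(NS(=O)(=O)c2ccc(N3CCNC3=O)cc2)cc1` gives 450 nM in a functional assay on M21 cells (Homo sapiens) for antiproliferative activity, read by sulforhodamine B assay, with a stated time of 48 h; on this read-out higher numbers stand for weaker inhibition and lower numbers for stronger inhibition.
Compound 2 `Cc1ccc(NS(=O)(=O)c2ccc(N3CCNC3=O)cc2)cc1C` gives 94 nM in this assay.
Compound 3 `O=C1NCCN1c1ccc(S(=O)(=O)Nc2ccc(F)c(F)c2)cc1` gives 220 nM in this assay.

Compound 2 stands lowest of the three numbers in this assay; compound 3 is its nearest neighbour, and compound 1 lies furthest away with a clearly higher number. Compound 4 `O=C1NCCN1c1ccc(S(=O)(=O)Nc2ccc(Cl)cc2)cc1` differs from compound 2 by 4-chlorophenyl in place of 3,4-dimethylphenyl on a sulfonamide nitrogen. Within the data shown here, only one measured step bears on this change: a 2.3-fold higher number from compound 2 to compound 3 (0.37 log units; beyond the scatter), where a halogen-bearing phenyl likewise replaced the 3,4-dimethylphenyl. On that basis a modest rise in the number, similar in size to that step, is expected in this assay, namely a 2.1-fold higher number from compound 2 to compound 4 (0.33 log units; beyond the scatter). Compound 4 is therefore estimated at 200 nM in this assay, with a likely range from 80 nM to 500 nM.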

Compound 4, half-maximal inhibitory concentration: 90 nM
The estimate for compound 4 lay 2.2-fold (0.35 log units) above the measured number; the measured number falls inside the stated range.
By their numbers in this assay, from the lowest: compounds 4 and 2 (each within the scatter of the next); then compound 3; then compound 1.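

Placing 4-chlorophenyl in place of 3,4-dimethylphenyl on the sulfonamide nitrogen gives a 1.0-fold lower number from compound 2 to compound 4 (0.02 log units; within the scatter) in this assay and so shows that a halogen-bearing phenyl need not raise the number at this place. The halogens also differ among themselves, since 4-chlorophenyl in place of 3,4-difluorophenyl gives a 2.4-fold lower number from compound 3 to compound 4 (0.39 log units; beyond the scatter) and chloro in place of butyl on an aromatic carbon gives a 5.0-fold lower number from compound 1 to compound 4 (0.70 log units; beyond the scatter) on the same read-out. No measurement shown explains these steps.

Left open is how a methoxy, an amine or a carboxylic acid in place of the chloro would read in this assay and whether these steps hold in another cell line.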